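Swapping Dimethylamino for Chloro on the Aryl Ring

This account rests on a few compounds, and the source may have more. Where it says the series, first, only, none or still open, it means among the compounds named here.

Compound 1, `COc1ccc(/C=N/NC(=S)NC(C)(C)[C@H]2CC=C(C)CC2)cc1`: 43800 nM
Compound 2, `CC1=CC[C@H](C(C)(C)NC(=S)N/N=C/c2ccc(O)cc2)CC1`: 82100 nM
Compound 3, `CC1=CC[C@H](C(C)(C)NC(=S)N/N=C/c2ccc(N(C)C)cc2)CC1`: > 100000 nM

All three share one core and differ only in the group on the aromatic ring. In a functional assay on NCI/ADR-RES cells (Homo sapiens) for inhibition, read by sulforhodamine B assay, with a stated time of 48 h (a lower number here means a stronger inhibitor of growth, a higher number a weaker inhibitor of growth), compound 3 reaches only a limit of the assay, because of the limit of > 100000 nM in this assay, at which 1 of the 3 values shown sits, so no number is known for it. Compound 4, `CC1=CC[C@H](C(C)(C)NC(=S)N/N=C/c2ccc(Cl)cc2)CC1`, differs from compound 3 by chloro in place of dimethylamino on an aromatic carbon. Two measured steps lead into compound 3: an at least 2.2-fold higher number from compound 1 to compound 3 (0.35 log units; beyond the scatter) and an at least 1.2-fold higher number from compound 2 to compound 3 (0.08 log units; that floor lies within the scatter). Both end at the limit, so removing the dimethylamino group is expected to lower the number, with the chloro compound landing somewhere near compound 1. Compound 4 is therefore expected near 50000 nM, within a range from 20000 nM to 150000 nM. That estimate means a step of an at least 2.0-fold lower number from compound 3 to compound 4 (0.30 log units; that floor lies within the scatter).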

Compound 4, concentration for 50% growth inhibition: 65200 nM
The estimate for compound 4 lay 1.3-fold (0.12 log units) below the measured number; low and high end bracket the measured number.
By their numbers in this assay, from the lowest: compounds 1, 4 and 2 (each within the scatter of the next). At a limit, above all of these: compound 3.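

In this assay, chloro, which has no hydrogen-bond donors or acceptors, cannot be told apart from hydroxy or methoxy on this aromatic carbon: the data show a 1.3-fold lower number from compound 2 to compound 4 (0.10 log units; within the scatter) and a 1.5-fold higher number from compound 1 to compound 4 (0.17 log units; within the scatter). Swapping among these three groups therefore gives no clear change in growth inhibition. From the compounds shown here alone, the third step, an at least 1.5-fold lower number from compound 3 to compound 4 (0.18 log units; that floor lies within the scatter), starts from a limit, so its true size remains unknown.

Going by these compounds, whether an amine, a carboxylic acid or a longer chain at this position would shift the number beyond the scatter remains open.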